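The compounds below may be only part of what the source reports. "The series", "measured", "known", "first", "only" and "open" are said of these compounds alone.

Measured compounds in a functional assay on HL-60 cells (Homo sapiens) for antiproliferative activity, read by XTT assay, with a stated time of 72 h; a higher number here means a weaker inhibitor, a lower number a stronger inhibitor:
compound 1 `Nc1nc2c(c(-c3ccccc3)cn2[C@@H]2O[C@H](CO)[C@@H](O)[C@H]2O)c(=O)[nH]1`: > 20000 nM
compound 2 `Nc1nc2c(c(-c3ccco3)cn2[C@@H]2O[C@H](CO)[C@@H](O)[C@H]2O)c(=O)[nH]1`: > 20000 nM

Both numbers are limits of this assay rather than measured values. Compound 1 reaches only the limit > 20000 nM. Compound 2 likewise reaches only the limit > 20000 nM, so compound 2 has no number of its own in this assay, only a limit. For the measured compounds named here, the one measured step, a step that the two limits leave unreadable from compound 1 to compound 2, cannot be given a size, since both of its ends sit at the same limit (the limit of > 20000 nM in this assay, at which 2 of the 2 values shown sit).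

Compound 3 `Nc1nc2c(c(-c3ccsc3)cn2[C@@H]2O[C@H](CO)[C@@H](O)[C@H]2O)c(=O)[nH]1` is not yet measured. It differs from compound 2 in one place: thiophen-3-yl in place of furan-2-yl on an aromatic carbon. Going by the values given here, the only measured step that bears on this change gives no readable size, so there is nothing in the data to suggest that the new ring would bring compound 3 into the readable range of this assay. The expectation is therefore that compound 3 also sits at the limit, an estimated step that the limit leaves unreadable from compound 2 to compound 3. Compound 3 is expected to give about 40000 nM, between 15000 nM and 200000 nM.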

Compound 3, half-maximal inhibitory concentration: > 20000 nM
Compound 3 was reported as a limit; the forecaster's own chance of this, stated with the estimate: 85%; the middle value is on the limit's open side.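

In this assay compound 3 gives > 20000 nM, which is a limit and not a number. The steps linking compound 3 with compound 1 and compound 2 therefore cannot be read, and all three compounds share one limit: the limit of > 20000 nM in this assay, at which 3 of the 3 values shown sit.

The compounds shown leave open how the phenyl, furan-2-yl and thiophen-3-yl groups compare, and whether any of them allows a readable value.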